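Chloro to Methoxy: Expecting the Number for Compound 3

This account rests on a few compounds, and the source may have more. Where it says the series, first, only, none or still open, it means among the compounds named here.

Measured so far:
compound 1, `CCNc1nnc(-c2nsc3ccccc23)o1`: 65%
compound 2, `Clc1ccc(Nc2nnc(-c3nsc4ccccc34)o2)cc1`: 48%

Going by the values given here, in a functional assay on the whole organism for inhibition, with Rattus norvegicus as the target, with a stated time of 2 h, at a dose of 100 mg/kg by the intraperitoneal route (on this read-out lower numbers stand for less inhibition and higher numbers for more inhibition at the one dose given (going by the name of the read-out)), compound 2 stands as the lowest of the two numbers measured; its only neighbour is compound 1, and the step of a number 17 percentage points lower from compound 1 to compound 2 (beyond the scatter) lies beyond the scatter. Compound 3, `COc1ccc(Nc2nnc(-c3nsc4ccccc34)o2)cc1`, differs from compound 2 in one place: methoxy in place of chloro on an aromatic carbon.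

Among the compounds with values here, no measured step bears directly on this change. Within the data shown here, the single step available, from compound 1 to compound 2, swapped ethyl for 4-chlorophenyl on a nitrogen and was modest in size; it says nothing about exchanging one group for another on the six-membered ring itself. With no guide of this kind, the step is expected to stay within the scatter, giving a number 1 percentage points lower from compound 2 to compound 3 (within the scatter). Compound 3 is therefore estimated at 47%, with a range from 28% to 66%.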

Compound 3, a percentage reported as inhibition, in the whole organism at one dose (the size of the read-out at that dose, not a potency): 59%
Compound 3: the middle estimate sits 12 percentage points below what was measured, and the stated range covers the measured number.
By their numbers in this assay, from the lowest: compound 2; then compounds 3 and 1 (each within the scatter of the next).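

At this place on the aromatic ring, para to a large group, the choice of substituent changes the result: in this assay, the swap of chloro for methoxy gives a number 11 percentage points higher from compound 2 to compound 3 (beyond the scatter), with everything else in the molecule unchanged. Going by these compounds alone, the earlier step changed the group on the nitrogen, so this is the first sign that the ring substituent alone can move the number. Methoxy has one more heavy atom than chloro and adds a hydrogen-bond acceptor, but no available measurement explains the step.

The compounds shown leave open whether other groups at this place, such as an amine or a methyl, would fall nearer compound 2 or compound 3. They also do not show whether a longer chain, such as ethoxy, would behave like methoxy.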